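Amino for Bromo on the Fused Core

The compounds below may be only part of what the source reports. "The series", "measured", "known", "first", "only" and "open" are said of these compounds alone.

Going by the values given here, in an assay on isolated protein for inhibition of tyrosine-protein kinase receptor UFO (Homo sapiens), with a stated time of 1.5 h (on this read-out higher numbers stand for weaker inhibition and lower numbers for stronger inhibition), compound 2 `Cn1cc(-c2n[nH]c3cc(Br)ccc23)cn1` gives 950 nM, the lower of the two numbers measured so far. Where compound 2 carries bromo, compound 1 `CC(C)Nc1ccc2c(-c3cnn(C)c3)n[nH]c2c1` carries isopropylamino; compound 1 gives 46600 nM, and the only measured step is a 49-fold lower number from compound 1 to compound 2 (1.69 log units; beyond the scatter). Compound 3 `Cn1cc(-c2n[nH]c3cc(N)ccc23)cn1` has amino in place of bromo on an aromatic carbon. Among the compounds with values here, that one step is the sole guide: a nitrogen-linked group in this place gave a much higher number than bromo, so compound 3 is expected to move by a 9.5-fold higher number from compound 2 to compound 3 (0.98 log units; beyond the scatter) toward a weaker value. The estimate for compound 3 is 9000 nM, with a range from 2000 nM to 40000 nM.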

Compound 3, half-maximal inhibitory concentration: 28800 nM
For compound 3 the middle estimate is 3.2-fold (0.51 log units) below the measured one; the measured number falls inside the stated range.
By their numbers in this assay, from the lowest: compound 2; then compounds 3 and 1 (each within the scatter of the next).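

In this assay, the higher number seen on leaving bromo also appears with amino, the smaller of the two nitrogen-linked groups, as a 30-fold higher number from compound 2 to compound 3 (1.48 log units; beyond the scatter) shows. It therefore does not require the isopropyl on the nitrogen: the step that removes this group, a 1.6-fold lower number from compound 1 to compound 3 (0.21 log units; within the scatter), stays within the scatter. Nothing available here accounts for the gap between bromo and these nitrogen-linked groups. The compounds shown leave open whether chloro, methyl or a nitrile would give a number like that of bromo. They also leave open whether an acetamide on this carbon would behave like amino.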